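Swapping an amide for a benzyl ester on compound 3's side chain

The source may hold more compounds than are shown below. What is called first, only, known or untested is meant among the compounds shown, and "the series" means these compounds.

Going by the values given here, the three compounds measured so far share one core and differ only in the side chain attached through an amide. Compound 1 `NC(=O)C[C@H](NC(=O)CN(c1nc(Cl)nc2c1ncn2C1CCCCO1)C1CC1)C(=O)OCc1ccccc1` gives 35% in a functional assay on the whole organism with Mus musculus as the target, with a stated time of 90 min, at a dose of 25 umol/kg by the oral route; a higher number here means a stronger effect of the compound at the dose given, a lower number a weaker effect. Compound 2 `O=C(CN(c1nc(Cl)nc2c1ncn2C1CCCCO1)C1CC1)N[C@@H](CC(=O)OCc1ccccc1)C(=O)OCc1ccccc1` gives 25.1%. Compound 3 `NC(=O)CC[C@H](NC(=O)CN(c1nc(Cl)nc2c1ncn2C1CCCCO1)C1CC1)C(=O)OCc1ccccc1` gives 37.8%. Compound 3 stands at the highest of the three numbers: its step from compound 1 is a number 2.8 percentage points higher from compound 1 to compound 3 (within the scatter), so these two cannot be told apart, while the step of a number 12.7 percentage points higher from compound 2 to compound 3 (beyond the scatter) sets compound 3 clearly apart from compound 2.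

Compound 4 `O=C(CN(c1nc(Cl)nc2c1ncn2C1CCCCO1)C1CC1)N[C@@H](CCC(=O)OCc1ccccc1)C(=O)OCc1ccccc1` has not yet been measured. It differs from compound 3 in one place: benzyloxy in place of amino on a carbonyl carbon. The measured step that bears most directly on this change is a number 9.9 percentage points lower from compound 1 to compound 2 (within the scatter), where the same exchange of amino for benzyloxy on a carbonyl carbon was made on the shorter side chain of compound 1. That step was small and within the scatter, so a similar small downward drift, rather than any clear change, is expected here.

Compound 4 is therefore estimated to give 30%, within a range from 18% to 42%, an expected step of a number 7.8 percentage points lower from compound 3 to compound 4 (within the scatter).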

Compound 4, a percentage reported as activity, at one dose (the size of the read-out at that dose, not a potency): 25.2%
Compound 4: middle estimate off by 4.8 percentage points, on the high side; the measured number falls inside the stated range.
By their numbers in this assay, from the lowest: compounds 2, 4, 1 and 3 (each within the scatter of the next, the first and the last beyond it).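

The exchange of amino for benzyloxy on a carbonyl carbon now has a second reading in this assay, on the longer side chain, and there the step is a number 12.6 percentage points lower from compound 3 to compound 4 (beyond the scatter), so the change now shows a drop that the shorter chain alone could not establish. The two readings agree in direction and size: the same change on two cores in this assay, a number 9.9 percentage points lower (within the scatter) from compound 1 to compound 2 and a number 12.6 percentage points lower (beyond the scatter) from compound 3 to compound 4, 2.7 percentage points apart, within the scatter of two such steps Once both side-chain ends carry benzyl esters, the extra chain carbon leaves no readable difference, with a number 0.1 percentage points higher from compound 2 to compound 4 (within the scatter), and the step that changes both the chain and the end group, a number 9.8 percentage points lower from compound 1 to compound 4 (within the scatter), does not separate those two compounds either.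

As far as these compounds go, it remains open how a free carboxylic acid or a small methyl ester would read in place of the benzyl ester on this side chain, and whether a longer chain would behave like the two seen here. The shared core and the benzyl ester on the other carbonyl are the same in all four compounds, so these results say nothing about what changing either of them would do.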